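The compounds below may be only part of what the source reports. "The series", "measured", "known", "first", "only" and "open" are said of these compounds alone.

Three ureas sharing one core have been measured in a functional assay on HepG2 cells (Homo sapiens) for inhibition, read by MTT assay, with a stated time of 72 h; a higher number here means a weaker inhibitor, a lower number a stronger inhibitor. Compound 1 `O=C(Nc1cccc(OCc2cn(-c3ccccc3)nn2)c1)Nc1ccc(Cl)c(C(F)(F)F)c1` gives 1780 nM, compound 2 `COc1ccc(-n2cc(COc3cccc(NC(=O)Nc4ccc(Cl)c(C(F)(F)F)c4)c3)nn2)cc1` gives 4680 nM, and compound 3 `CCc1cccc(-n2cc(COc3cccc(NC(=O)Nc4ccc(Cl)c(C(F)(F)F)c4)c3)nn2)c1` gives 37900 nM. Compound 2 therefore stands second highest of the three numbers: of the two steps that touch it, a 2.6-fold higher number from compound 1 to compound 2 (0.42 log units; beyond the scatter) is the smaller and an 8.1-fold higher number from compound 2 to compound 3 (0.91 log units; beyond the scatter) the larger. Compound 4 `CCc1ccc(-n2cc(COc3cccc(NC(=O)Nc4ccc(Cl)c(C(F)(F)F)c4)c3)nn2)cc1` differs from compound 2 by ethyl in place of methoxy on an aromatic carbon. For the measured compounds named here, two measured steps bear on this change, a 2.6-fold higher number from compound 1 to compound 2 (0.42 log units; beyond the scatter) and a 21-fold higher number from compound 1 to compound 3 (1.33 log units; beyond the scatter), the step with ethyl being the larger, although compound 3 is the 3-ethylphenyl compound. A modest step toward a higher number is therefore expected, a 2.1-fold higher number from compound 2 to compound 4 (0.33 log units; beyond the scatter). Compound 4 is estimated at 10000 nM in this assay, within 3500 nM to 30000 nM.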

Compound 4, half-maximal inhibitory concentration: 1950 nM
For compound 4 the middle estimate is 5.1-fold (0.71 log units) above the measured one, and the stated range ends above it.
By their numbers in this assay, from the lowest: compounds 1 and 4 (each within the scatter of the next); then compound 2; then compound 3.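

The step of a 19-fold lower number from compound 3 to compound 4 (1.29 log units; beyond the scatter) shows that the weak value of compound 3 belongs to the 3-ethylphenyl group and not to ethyl as such. The step of a 1.1-fold higher number from compound 1 to compound 4 (0.04 log units; within the scatter) lies within the scatter, so the 4-ethylphenyl group cannot be told apart from plain phenyl. The step of a 2.4-fold lower number from compound 2 to compound 4 (0.38 log units; beyond the scatter) places ethyl ahead of methoxy on this aromatic carbon.

Going by these compounds, whether an amine, a carboxylic acid or a propyl chain here would behave like ethyl or like methoxy stays open. Nothing given here accounts for these differences.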